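This account rests on a few compounds, and the source may have more. Where it says the series, first, only, none or still open, it means among the compounds named here.

In an ADME assay on SH-SY5Y cells (Homo sapiens) for cytotoxicity, read by MTT assay, with a stated time of 72 h (on this read-out lower numbers stand for stronger inhibition and higher numbers for weaker inhibition), compound 1 `COc1ccc(C(=O)N2CCN(CC(=O)N3CCN(CCCc4c[nH]c5ccccc45)CC3)CC2)cc1` gives 148000 nM as its measured value. Compound 2 `COc1cccc(C(=O)N2CCN(CC(=O)N3CCN(CCCc4c[nH]c5ccccc45)CC3)CC2)c1` stands at > 200000 nM and that is a limit of the assay, not a number. Compound 3 `O=C(CN1CCN(C(=O)c2cccc(Br)c2)CC1)N1CCN(CCCc2c[nH]c3ccccc23)CC1` has bromo in place of methoxy on an aromatic carbon. Within the data shown here, the one measured step (an at least 1.3-fold higher number from compound 1 to compound 2 (0.13 log units; that floor lies within the scatter)) only compares 3-methoxyphenyl with 4-methoxyphenyl, and its floor lies within the scatter, so it offers little guidance on bromo. No step beyond the scatter is therefore expected in this assay for this change. The expected step is small (an at least 1.3-fold lower number from compound 2 to compound 3 (0.12 log units; that floor lies within the scatter)). Compound 3 is estimated at 150000 nM (expected range 70000 nM to 300000 nM).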

Compound 3, half-maximal inhibitory concentration: 80500 nM
Estimate against measurement, compound 3: 1.9-fold (0.27 log units) above, and the stated range covers the measured number.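

Bromo in place of methoxy on this aromatic carbon gives an at least 2.4-fold lower number from compound 2 to compound 3 (0.39 log units; beyond the scatter) in this assay, the first step shown that clears the scatter. Compound 2 carries only a limit, so this size is a floor and not an exact figure: the limit of > 200000 nM in this assay, at which 1 of the 3 values shown sits. The other comparison, 3-bromophenyl in place of 4-methoxyphenyl, shows a 1.8-fold lower number from compound 1 to compound 3 (0.26 log units; within the scatter), so these two groups cannot be told apart here. Going by these compounds, whether fluoro, chloro or an amine on this carbon would shift the number remains open. So does what bromo would do where compound 1 carries its methoxy.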